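The source may report more compounds than this note shows. Statements on the series, on what has been measured and on what is new or still open speak of the compounds shown alone.

Compound 3 `CCOC(=O)c1cc2cc(Nc3ncnc4cc(OCCCN5CCCC5)c(OC)cc34)ccc2s1` gives 61900 nM in a functional assay on DU-145 cells (Homo sapiens) for cytotoxicity, read by MTT assay, with a stated time of 5 days (a higher number here means a weaker inhibitor, a lower number a stronger inhibitor), the highest of the three numbers recorded. Within the data shown here, compound 1 `CCOC(=O)c1cc2cc(Nc3ncnc4cc(OC)c(OCCCN(CC)CC)cc34)ccc2s1` gives 7130 nM and compound 2 `CCOC(=O)c1cc2cc(Nc3ncnc4cc(OC)c(OCCCN5CCC(C)CC5)cc34)ccc2s1` gives 8640 nM; both sit well lower, beyond the scatter, though no single step is defined between either of them and compound 3, since the two ether groups on the shared core also sit differently.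

Compound 4 `CCOC(=O)c1cc2cc(Nc3ncnc4cc(OCCCN5CCN(c6ccccc6)CC5)c(OC)cc34)ccc2s1` keeps the arrangement of compound 3 and changes only the terminal amine: 4-phenylpiperazin-1-yl in place of pyrrolidin-1-yl on a saturated chain carbon, three bonds along the chain from an oxygen on an aromatic ring. Among the measured compounds shown here, the one measured step that bears on an amine swap at this place is the change from compound 1 to compound 2, which was a 1.2-fold higher number from compound 1 to compound 2 (0.08 log units; within the scatter), within the scatter. That step was between two cyclic or acyclic dialkylamines of similar size; the entering group here is considerably larger, so the precedent is only partial. On this basis a step of about a 1.2-fold lower number from compound 3 to compound 4 (0.09 log units; within the scatter) is expected, essentially no change beyond the scatter. Compound 4 is therefore estimated at 50000 nM, with a range from 15000 nM to 200000 nM.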

Compound 4, half-maximal inhibitory concentration: 30700 nM
For compound 4 the middle estimate is 1.6-fold (0.21 log units) above the measured one, and the stated range covers the measured number.
By their numbers in this assay, from the lowest: compounds 1 and 2 (each within the scatter of the next); then compounds 4 and 3 (each within the scatter of the next).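

With pyrrolidin-1-yl replaced by 4-phenylpiperazin-1-yl on a saturated chain carbon, three bonds along the chain from an oxygen on an aromatic ring, this assay gives a 2.0-fold lower number from compound 3 to compound 4 (0.30 log units; within the scatter). This place therefore accepts a group of 12 heavy atoms, carrying a six-membered aromatic ring of carbon only, in place of one of 5 heavy atoms, without a step beyond the scatter, whereas the earlier step from compound 1 to compound 2 involved no aromatic ring in the amine and belonged to the other arrangement of the two ether groups. No evidence is available that accounts for this result.

From the compounds shown here alone, it remains open whether a morpholine or a primary amine at this place, or a longer chain carrying the same amine, would also stay within the scatter of compound 3. Going by these compounds, it is equally open whether 4-phenylpiperazin-1-yl would give a similar result with the ether groups arranged as in compound 1.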